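The source may hold more compounds than are shown below. What is called first, only, known or untested is meant among the compounds shown, and "the series" means these compounds.

Compound 1 `CN1CCN(CCn2c(N)c(-c3nc4ccccc4[nH]3)c3nc(C#N)c(C#N)nc32)CC1`: 6550 nM
Compound 2 `CN1CCN(CCCn2c(N)c(-c3nc4ccccc4[nH]3)c3nc(C#N)c(C#N)nc32)CC1`: 1260 nM

Both values come from a functional assay on K562 cells (Homo sapiens) for antiproliferative activity, read by MTT assay, with a stated time of 48 h; on this read-out higher numbers stand for weaker inhibition and lower numbers for stronger inhibition. Compound 2 has the lower of the two numbers, making it the stronger inhibitor of this pair and the starting point for the next comparison. Compound 3 `N#Cc1nc2c(-c3nc4ccccc4[nH]3)c(N)n(CCCN3CCCCC3)c2nc1C#N` keeps the shared core of compound 2 but carries piperidin-1-yl in place of 4-methylpiperazin-1-yl, on a saturated chain carbon, three bonds along the chain from an aromatic nitrogen: piperidin-1-yl in place of 4-methylpiperazin-1-yl on a saturated chain carbon, three bonds along the chain from an aromatic nitrogen.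

Going by the values given here, only one measured step bears on this change, and only indirectly. Lengthening the chain gave a 5.2-fold lower number from compound 1 to compound 2 (0.72 log units; beyond the scatter), a modest change beyond the scatter. That step kept the 4-methylpiperazin-1-yl group, so no measurement here shows what replacing this group does. With no evidence for a direction, no step beyond the scatter is expected in this assay, although the uncertainty is wide. The estimated change is a 1.1-fold lower number from compound 2 to compound 3 (0.02 log units; within the scatter). Compound 3 is expected at 1200 nM, with an estimated range of 400 nM to 3600 nM.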

Compound 3, half-maximal inhibitory concentration: 3460 nM
For compound 3 the middle estimate is 2.9-fold (0.46 log units) below the measured one; measured number inside the range.
By their numbers in this assay, from the lowest: compound 2; then compounds 3 and 1 (each within the scatter of the next).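

In this assay, going by these compounds alone, this is the first look at the end group itself, and the position responds to it: 3-(piperidin-1-yl)propyl, whose ring holds one nitrogen, in place of 3-(4-methylpiperazin-1-yl)propyl, whose ring holds two, gives a 2.7-fold higher number from compound 2 to compound 3 (0.44 log units; beyond the scatter). The comparison with the shorter chain gives a 1.9-fold lower number from compound 1 to compound 3 (0.28 log units; within the scatter), so these two compounds cannot be told apart here, and among the compounds shown, only the combination in compound 2 stands clearly apart from the others. Nothing available explains why the end group changes the result.

As far as these compounds go, it remains open which part of the 4-methylpiperazin-1-yl group matters, the methyl or the second ring nitrogen; a piperazin-1-yl group without the methyl, or a morpholin-4-yl group, on the same chain would help separate the two. Also open, from the compounds shown here alone, is whether the two end groups would keep this order on other chains, such as 2-(piperidin-1-yl)ethyl or a butyl chain ending in either ring.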